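This account rests on a few compounds, and the source may have more. Where it says the series, first, only, none or still open, it means among the compounds named here.

Working notes on the series in a functional assay on PC-3 cells (Homo sapiens) for inhibition; on this read-out lower numbers stand for stronger inhibition and higher numbers for weaker inhibition.

Compound 1 `Cc1c(C(=O)N/N=C\c2ccc(O)cc2)oc2cccc(O)c12` gives 21700 nM in this assay, and compound 2 `COc1ccccc1/C=N\NC(=O)c1oc2cccc(O)c2c1C` gives 32700 nM. Compound 3 `COc1cccc(/C=N\NC(=O)c2oc3cccc(O)c3c2C)c1` reaches only a limit of this assay, >= 40000 nM; it stands at the limit of >= 40000 nM in this assay, at which 1 of the 3 values shown sits. The steps of a 1.5-fold higher number from compound 1 to compound 2 (0.18 log units; within the scatter), an at least 1.8-fold higher number from compound 1 to compound 3 (0.26 log units; that floor lies within the scatter) and an at least 1.2-fold higher number from compound 2 to compound 3 (0.08 log units; that floor lies within the scatter) all stay within the scatter, so the three measured compounds sit together on the weak side of this assay.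

Compound 4 `Cc1c(C(=O)N/N=C\c2ccc(Br)cc2O)oc2cccc(O)c12` carries the change (4-bromo-2-hydroxyphenyl in place of 3-methoxyphenyl on a carbon with a double bond to nitrogen). Among the compounds with values here, no measured step covers a hydroxyl together with a bromine on this ring; the three measured steps, all within the scatter, give no ground for a step beyond the scatter in this assay. The value of compound 4 is therefore estimated at 25000 nM, with a range from 8000 nM to 60000 nM. The expected step of an at least 1.6-fold lower number from compound 3 to compound 4 (0.20 log units; that floor lies within the scatter) is thus within the scatter, and since compound 3 is known only as a limit, a limit for compound 4 remains possible.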

Compound 4, half-maximal inhibitory concentration: 2050 nM
The estimate for compound 4 lay 12-fold (1.09 log units) above the measured number; measured number below the stated range.
By their numbers in this assay, from the lowest: compound 4; then compounds 1 and 2 (each within the scatter of the next). At a limit, above all of these: compound 3.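

In this assay the group on a carbon with a double bond to nitrogen can move the read-out well beyond the scatter, with 4-bromo-2-hydroxyphenyl giving large steps (an 11-fold lower number from compound 1 to compound 4 (1.02 log units; beyond the scatter); a 16-fold lower number from compound 2 to compound 4 (1.20 log units; beyond the scatter); an at least 19-fold lower number from compound 3 to compound 4 (1.29 log units; beyond the scatter)). Among the earlier compounds, 4-hydroxyphenyl, 2-methoxyphenyl and 3-methoxyphenyl stayed within the scatter of one another. The step from compound 3 is a floor, as compound 3 is only a limit: the limit of >= 40000 nM in this assay, at which 1 of the 4 values shown sits.

The compounds shown do not separate the contribution of the bromine from that of the hydroxyl. On these data alone, how an amine or a carboxylic acid in place of the bromine would read also stays open.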